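Swapping chloro for methyl on a weak amine

The source may report more compounds than this note shows. Statements on the series, on what has been measured and on what is new or still open speak of the compounds shown alone.

Compound 1 `C/C=C/C(=O)N(Cc1ccc(OC)c([N+](=O)[O-])c1)c1cc(OC)c(OC)c(OC)c1`: 670 nM
Compound 2 `COc1cc(NCc2ccccc2)cc(OC)c1OC`: > 80000 nM (a limit, not a number)
Compound 3 `COc1ccc(CNc2cc(OC)c(OC)c(OC)c2)cc1Cl`: 41700 nM

In a functional assay on HCT-116 cells (Homo sapiens) for inhibition, read by MTT assay, with a stated time of 48 h (a lower number here means a stronger inhibitor, a higher number a weaker inhibitor), only two of these compounds have actual numbers. Compound 3 gives the higher of them at 41700 nM, and the gap to compound 1 at 670 nM lies beyond the scatter. Compound 2 has no number, only (the limit of > 80000 nM in this assay, at which 1 of the 3 values shown sits).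

The next compound to be tested is compound 4 `COc1ccc(CNc2cc(OC)c(OC)c(OC)c2)cc1C`, which has methyl in place of chloro on an aromatic carbon. The exchange takes place ortho to a methoxy group and meta to a large group. Within the data shown here, no measured pair in this small set shows what such an exchange does, so the expectation rests on compound 3 at 41700 nM. In this assay no change beyond the scatter is expected, and the estimated step is a 1.1-fold higher number from compound 3 to compound 4 (0.03 log units; within the scatter). For compound 4 the estimate is 45000 nM, with an expected range from 18000 nM to 80000 nM.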

Compound 4, half-maximal inhibitory concentration: 60900 nM
The estimate for compound 4 lay 1.4-fold (0.13 log units) below the measured number; the range from low to high includes it.
By their numbers in this assay, from the lowest: compound 1; then compounds 3 and 4 (each within the scatter of the next). At a limit, above all of these: compound 2.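

In this assay, among these compounds, the exchange of chloro for methyl gives a 1.5-fold higher number from compound 3 to compound 4 (0.16 log units; within the scatter), the first step in this set that can be read between two compounds differing in one place. At this position, ortho to a methoxy group and meta to a large group, the two groups are therefore not told apart by this read-out, and the swap of one heavy atom for another leaves the compound in the same range. Nothing measured in this set bears on why the two groups give such similar results.

A single exchange cannot show whether this position tolerates change in general or merely does not distinguish these two groups. A nitrile, a hydroxyl or a longer chain such as ethyl at the same carbon might still move the number beyond the scatter, and the compounds shown do not settle that.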